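Removing the Amino from Compound 3's Amide Nitrogen

The compounds below may be only part of what the source reports. "The series", "measured", "known", "first", "only" and "open" are said of these compounds alone.

Measured compounds in an ADME assay on a cell-free system (plasma, Homo sapiens) for metabolic stability, read by LC-MS, tested at 10 ug/mL; a higher number here means that the compound lasts longer, a lower number that the compound disappears faster: compound 1 `COCCOC(=O)c1cc(N)c(Nc2ccc(C#N)cc2)cc1Oc1c(C)cc(/C=C/C#N)cc1C` gives 62 h; compound 2 `CCNC(=O)c1cc(N)c(Nc2ccc(C#N)cc2)cc1Oc1c(C)cc(/C=C/C#N)cc1C` gives 91 h; compound 3 `Cc1cc(/C=C/C#N)cc(C)c1Oc1cc(Nc2ccc(C#N)cc2)c(N)cc1C(=O)NN` gives 8 h.

Compound 3 stands lowest of the three; the nearest, compound 1, lies a 7.8-fold lower number from compound 1 to compound 3 (0.89 log units; beyond the scatter) away, and compound 2 lies an 11-fold lower number from compound 2 to compound 3 (1.06 log units; beyond the scatter) away. Compound 4 `Cc1cc(/C=C/C#N)cc(C)c1Oc1cc(Nc2ccc(C#N)cc2)c(N)cc1C(N)=O` differs from compound 3 by hydrogen in place of amino on an amide-type nitrogen, turning aminocarbamoyl into carbamoyl. The step that bears on it is the one that put the amino there: the change from compound 2 to compound 3 was large, and compound 4 undoes part of that change while keeping a hydrogen instead of ethyl. A large step upward in this assay is therefore expected, though not necessarily all the way back to compound 2. Compound 4 is expected to give 55 h, within 22 h to 130 h. That expected step is a 6.9-fold higher number from compound 3 to compound 4 (0.84 log units; beyond the scatter).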

Compound 4, half-life: 65 h
The estimate for compound 4 lay 1.2-fold (0.07 log units) below the measured number; the range from low to high includes it.
By their numbers in this assay, from the lowest: compound 3; then compounds 1, 4 and 2 (each within the scatter of the next).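

Among these four compounds, only the amino on the amide-type nitrogen goes with a short half-life in this assay: replacing it with hydrogen gives a clear rise (an 8.1-fold higher number from compound 3 to compound 4 (0.91 log units; beyond the scatter)). Hydrogen and ethyl on that nitrogen give numbers that cannot be told apart (a 1.4-fold lower number from compound 2 to compound 4 (0.15 log units; within the scatter)). The same holds when amino replaces 2-methoxyethoxy on the carbonyl carbon (a 1.0-fold higher number from compound 1 to compound 4 (0.02 log units; within the scatter)).

Nothing shown explains why the amino has this effect.
Also open, from the compounds shown here alone, is whether a methyl group on that nitrogen, or a carboxylic acid in place of the amide, would keep the half-life long.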